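Dichlorophenyl variant of an inactive halogenated pair

The compounds below may be only part of what the source reports. "The series", "measured", "known", "first", "only" and "open" are said of these compounds alone.

Compound 1 `COc1cc(/C(=C/c2ccc(Cl)cc2)C(C)O)cc(OC)c1OC` sits at the limit of a functional assay on L1210 cells (Mus musculus) for antiproliferative activity, read by MTT assay, with a stated time of 72 h; on this read-out lower numbers stand for stronger inhibition and higher numbers for weaker inhibition: in that assay compound 1 gives > 100000 nM, a limit rather than a number. Compound 2 `COc1cc(/C(=C/c2ccc(Br)cc2)C(C)O)cc(OC)c1OC` likewise sits at the limit; in this assay compound 2 gives > 100000 nM, again a limit. The step that the two limits leave unreadable from compound 1 to compound 2 therefore cannot be read, since the limit of > 100000 nM in this assay, at which 2 of the 2 values shown sit, places both values at the same limit. Compound 2 thus stands at the limit of the shown data, with no number beneath it.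

Compound 3 `COc1cc(/C(=C/c2ccc(Cl)c(Cl)c2)C(C)O)cc(OC)c1OC` carries 3,4-dichlorophenyl in place of 4-bromophenyl on a double-bonded chain carbon bound to a double-bonded chain carbon. Going by the values given here, the only measured step bears on this change through its halogen swap alone, and its size is unreadable. No readable step gives a direction, so no movement beyond the scatter is expected in this assay, and compound 3 is expected to remain at or near the limit. The expected step that the limit leaves unreadable from compound 2 to compound 3 is estimated as essentially none. For compound 3 the estimate in this assay is 150000 nM, with a range from 40000 nM to 600000 nM.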

Compound 3, half-maximal inhibitory concentration: 18500 nM
The estimate for compound 3 lay 8.1-fold (0.91 log units) above the measured number, and the stated range ends above it.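

In this assay, the 3,4-dichlorophenyl group gives the first readable movement in the series, an at least 5.4-fold lower number from compound 2 to compound 3 (0.73 log units; beyond the scatter). Chloro in place of hydrogen on an aromatic carbon accounts for the other readable change, an at least 5.4-fold lower number from compound 1 to compound 3 (0.73 log units; beyond the scatter), which shows that the ring tolerates a further substituent at this place and that activity can then be measured. Both steps start from a limit, so each gives only a minimum size, and the step between compound 1 and compound 2 cannot be read: the limit of > 100000 nM in this assay, at which 2 of the 3 values shown sit.

The compounds shown leave open whether the change depends on a second halogen, which a methoxy group or an amine in place of the added chloro would address. Also open, as far as these compounds go, is the role of the chain alcohol of the shared core, which a ketone there would probe.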